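Aryl variation at the hydrazone carbon of the shared core

This account rests on a few compounds, and the source may have more. Where it says the series, first, only, none or still open, it means among the compounds named here.

Numbers in a functional assay on A549 cells (Homo sapiens) for cytotoxicity, read by MTT assay, with a stated time of 72 h (on this read-out lower numbers stand for stronger inhibition and higher numbers for weaker inhibition), so far:
compound 1 `CN(C)CCn1cnnc1-c1cc(Oc2ccc(NC(=O)N/N=C/c3c(Cl)cccc3Cl)cc2F)ccn1`: 1410 nM
compound 2 `CN(C)CCn1cnnc1-c1cc(Oc2ccc(NC(=O)N/N=C/c3c[nH]c4ccccc34)cc2F)ccn1`: 820 nM
compound 3 `CN(C)CCn1cnnc1-c1cc(Oc2ccc(NC(=O)N/N=C/c3cc(C(C)(C)C)cc(C(C)(C)C)c3O)cc2F)ccn1`: 980 nM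

Compound 2 gives the lowest of the three numbers, but compound 3 and compound 1 both sit within the scatter of it, so no ordering is claimed. Within the data shown here, the one single-point step in hand, a 1.7-fold lower number from compound 1 to compound 2 (0.24 log units; within the scatter), exchanges the aryl group on the carbon with a double bond to nitrogen and stays within the scatter. Compound 4 `COc1ccc(/C=N/NC(=O)Nc2ccc(Oc3ccnc(-c4nncn4CCN(C)C)c3)c(F)c2)c(OC)c1` differs from compound 2 by 2,4-dimethoxyphenyl in place of 1H-indol-3-yl on a carbon with a double bond to nitrogen. The step from compound 1 to compound 2 bears directly on this change and was small, and compound 3 carrying yet another aryl group in the same place also lies close, so no movement beyond the scatter is expected in this assay. Compound 4 is estimated at 1000 nM, range 450 nM to 2500 nM. This corresponds to an expected step of a 1.2-fold higher number from compound 2 to compound 4 (0.09 log units; within the scatter).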

Compound 4, half-maximal inhibitory concentration: 2820 nM
The estimate for compound 4 lay 2.8-fold (0.45 log units) below the measured number; measured number above the stated range.
By their numbers in this assay, from the lowest: compounds 2, 3, 1 and 4 (each within the scatter of the next, the first and the last beyond it).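

In this assay, the aryl group on the carbon with a double bond to nitrogen can move the number beyond the scatter: 2,4-dimethoxyphenyl in place of 1H-indol-3-yl gives a 3.4-fold higher number from compound 2 to compound 4 (0.54 log units; beyond the scatter) in this series. The same group in place of 2,6-dichlorophenyl gives a 2.0-fold higher number from compound 1 to compound 4 (0.30 log units; within the scatter), so the effect of this change depends on the group replaced. Nothing available explains the step from compound 2 to compound 4.

Still open, on these data alone, is whether 1-methylindol-3-yl, which lacks the indole hydrogen on nitrogen, would keep the number of compound 2. Also open, as far as these compounds go, is how an aryl group carrying an amine or a carboxylic acid would read at this carbon.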